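The source may report more compounds than this note shows. Statements on the series, on what has been measured and on what is new or still open speak of the compounds shown alone.

Compounds measured in an ADME assay on MT4 cells (Homo sapiens) for cytotoxicity, read by MTT assay, with a stated time of 5 days; a lower number here means that less compound is tolerated, a higher number that more compound is tolerated:

- Compound 1 `N#Cc1ccc(Nc2nccc(OCC(=O)Nc3ccc(Cl)cc3)n2)cc1`: 162000 nM
- Compound 2 `Cc1cc(OCC(=O)Nc2ccc(C#N)cc2F)nc(Nc2ccc(C#N)cc2)n1`: > 310000 nM, a limit
- Compound 3 `Cc1cnc(Nc2ccc(C#N)cc2)nc1OCC(=O)Nc1ccc(Cl)cc1`: > 317000 nM, a limit

Compound 3 has no exact number in this assay. Its > 317000 nM is a limit. Among the measured compounds shown here, compound 2 is the only other compound that gives a limit, and compound 1 is the only one of the three with an exact value.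

Compound 4 `Cc1cnc(Nc2ccc(C#N)cc2)nc1OCC(=O)Nc1ccc([N+](=O)[O-])cc1` has not yet been measured. It carries nitro in place of chloro on an aromatic carbon, para to a large group: nitro in place of chloro on an aromatic carbon.

For the measured compounds named here, no measured step makes this exchange. Going by the values given here, the single step available, an at least 1.9-fold higher number from compound 1 to compound 3 (0.29 log units; that floor lies within the scatter), is methyl in place of hydrogen on an aromatic carbon, elsewhere in the molecule, and its floor lies within the scatter. It offers only weak guidance, and no size for the nitro exchange can be taken from it. No step beyond the scatter is therefore expected in this assay. Compound 3 already stands at a limit, so any change that can be read would run toward a lower number, and compound 4 may also return a limit.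

The estimated change is an at least 1.4-fold lower number from compound 3 to compound 4 (0.15 log units; that floor lies within the scatter). For compound 4 the expected half-maximal cytotoxic concentration is 220000 nM, with an expected range of 70000 nM to 320000 nM.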

Compound 4, half-maximal cytotoxic concentration: 66300 nM
Compound 4: middle estimate off by 3.3-fold (0.52 log units), on the high side; the whole stated range lies above it.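

In this assay, nitro in place of chloro on an aromatic carbon, para to a large group, gives a step beyond the scatter: an at least 4.7-fold lower number from compound 3 to compound 4 (0.67 log units; beyond the scatter). That size is only a floor, and compound 3 has a limit here, not an exact number: the limit of > 317000 nM in this assay, at which 1 of the 4 values shown sits. The one earlier step, an at least 1.9-fold higher number from compound 1 to compound 3 (0.29 log units; that floor lies within the scatter), came from methyl in place of hydrogen elsewhere in the molecule and had a floor within the scatter, so the change from 4-chlorophenyl to 4-nitrophenyl is the first among these compounds to show that a single exchange can shift this read-out by more than the scatter, and it does so toward less compound tolerated.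

From the compounds shown here alone, whether the shift belongs to nitro itself or would also follow other groups at this place stays open, and an amine, a carboxylic acid or a methoxy group there would speak to that. Going by these compounds, it also stays open whether the same exchange gives a step of similar size on the core of compound 1, which lacks the methyl.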